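A few compounds are considered here, and "the series" means these few. Any claim that something is new, unique, unknown or untested is made for them only; others in the source may bear on it.

In a functional assay on MCF7 cells (Homo sapiens) for antiproliferative activity, read by MTT assay, with a stated time of 72 h (a higher number here means a weaker inhibitor, a lower number a stronger inhibitor), compound 1 `CCN(CC)CCNC(=O)c1cc(C(CC)(CC)c2ccc(C#CC(O)(CC)CC)c(C)c2)cn1CC` gives 1800 nM. Compound 2 `CCCCC(=O)c1cc(C(CC)(CC)c2ccc(C#CC(O)(CC)CC)c(C)c2)cn1CC` reads > 50000 nM, which is a limit and not a number. Compound 3 `CCn1cc(C(CC)(CC)c2ccc(C#CC(O)(CC)CC)c(C)c2)cc1C(=O)NCCC(=O)O` differs from it by (2-carboxyethyl)amino in place of butyl on a carbonyl carbon, with (2-carboxyethyl)amino in place of butyl on a carbonyl carbon. Among the measured compounds shown here, the only measured step bearing on this change is an at least 27-fold higher number from compound 1 to compound 2 (1.44 log units; beyond the scatter), which is large and beyond the scatter, and it runs the other way. Only part of that step is expected back, so a moderate move to a lower number is expected in this assay, with the expected step being an at least 1.6-fold lower number from compound 2 to compound 3 (0.22 log units; that floor lies within the scatter). Compound 3 is estimated at 30000 nM, within a range of 10000 nM to 60000 nM.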

Compound 3, half-maximal inhibitory concentration: 30600 nM
Compound 3: middle estimate off by 1.0-fold (0.01 log units), on the low side; measured number inside the range.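

In this assay, an amide on the carbonyl carbon does not by itself keep the number of compound 1: carboxy in place of diethylamino on the saturated chain gives a 17-fold higher number from compound 1 to compound 3 (1.23 log units; beyond the scatter). The step of an at least 1.6-fold lower number from compound 2 to compound 3 (0.21 log units; that floor lies within the scatter) does not separate (2-carboxyethyl)amino from butyl. Compound 2 stands at a limit, not a number: the limit of > 50000 nM in this assay, at which 1 of the 3 values shown sits.

Open, on these data alone, is whether the diethylamino group specifically carries the difference. A primary amine, a morpholine or a longer chain ahead of the diethylamino group would address this on the same side chain.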